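The compounds below may be only part of what the source reports. "The series", "measured", "known", "first", "only" and "open" are said of these compounds alone.

Going by the values given here, in an ADME assay on HEK293 cells (Homo sapiens) for cytotoxicity, read by resazurin assay, with a stated time of 48 h (on this read-out lower numbers stand for higher toxicity in this test and higher numbers for lower toxicity in this test), compound 1 `COc1ccc(S(=O)(=O)Nc2ccc3oc(-c4ccc(NC(=O)c5cccc(C)c5[N+](=O)[O-])cc4)nc3c2)cc1` gives 12000 nM and is the only compound with a true number so far. Compound 2 `O=S(=O)(Nc1ccc(-c2nc3cc(NS(=O)(=O)c4cccc5ccccc45)ccc3o2)cc1)c1cccc2ccccc12` gives > 100000 nM as its result, which is a limit of the assay and not a number.

Compound 3 `COc1ccc(S(=O)(=O)Nc2ccc3oc(-c4ccc(NS(=O)(=O)c5cc(Br)ccc5OC)cc4)nc3c2)cc1` keeps the core of compound 1 and replaces one group, with (5-bromo-2-methoxyphenyl)sulfonyl in place of (3-methyl-2-nitrophenyl)carbonyl on a nitrogen on an aromatic ring. The count (5-bromo-2-methoxyphenyl)sulfonyl in place of (3-methyl-2-nitrophenyl)carbonyl on a nitrogen on an aromatic ring sets out what leaves and what enters. Among the compounds with values here, no measured pair of compounds differs in just one place, so the size of this change in this assay cannot be read from an earlier step. The only hint of direction is compound 2 at its limit of > 100000 nM in the same test. A moderate rise is therefore expected, pointing towards lower toxicity, and the estimated size is a 2.5-fold higher number from compound 1 to compound 3 (0.40 log units; beyond the scatter) with wide uncertainty around it. For compound 3 the estimated half-maximal cytotoxic concentration is 30000 nM with a range from 8000 nM to 100000 nM as the expected spread.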

Compound 3, half-maximal cytotoxic concentration: 18000 nM
Beside the measured number, compound 3's estimate is 1.7-fold (0.22 log units) above it; the range from low to high includes it.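

In this assay, exchanging (3-methyl-2-nitrophenyl)carbonyl for (5-bromo-2-methoxyphenyl)sulfonyl on a nitrogen on an aromatic ring gives a 1.5-fold higher number from compound 1 to compound 3 (0.18 log units; within the scatter), so this test does not tell the two compounds apart. Going by these compounds alone, this is the first step that can be read at this position, and it shows that a carbonyl link and a sulfonyl link, each carrying its own substituted aromatic ring, give values within the usual scatter of each other. The two groups also match in their counts of heavy atoms, hydrogen-bond donors and hydrogen-bond acceptors, so this step says nothing about a group that differs from them in those counts.

From the compounds shown here alone, it remains open whether a simple acetyl group, or a chain ending in an amine or a carboxylic acid, on this nitrogen would move the number beyond the scatter, and whether the link or the ring substituents matter more, since both changed together here. Compound 2 gives a limit and not a number, and it differs from the other compounds in more than one place, so no step involving it can be read: the limit of > 100000 nM in this assay, at which 1 of the 3 values shown sits.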